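A few compounds are considered here, and "the series" means these few. Any claim that something is new, unique, unknown or untested is made for them only; others in the source may bear on it.

Measured so far:
compound 1 `Cc1ccccc1/C(CCN1CCN(c2ccccn2)CC1)=N/O` — 82%
compound 2 `N#Cc1cccc(/C(CCN2CCN(c3ccccn3)CC2)=N/O)c1` — 48%

Going by the values given here, in a functional assay on HEK293 cells with D(4) dopamine receptor (Homo sapiens) as the target, read by FLIPR (on this read-out higher numbers stand for larger maximal responses and lower numbers for smaller maximal responses), compound 2 stands lowest of the two numbers; the only measured step, a number 34 percentage points lower from compound 1 to compound 2 (beyond the scatter), is large and places compound 1 well above it. Compound 3 `O/N=C(\CCN1CCN(c2ccccn2)CC1)c1ccc(F)cc1` is not yet measured. Its change from compound 2 is 4-fluorophenyl in place of 3-cyanophenyl on a carbon with a double bond to nitrogen. The step of a number 34 percentage points lower from compound 1 to compound 2 (beyond the scatter) bears on it only in showing that exchanging the aryl group at this place can shift the maximal response substantially; it gives no direct reading for 4-fluorophenyl. A rise toward compound 1 is expected, by a number 17 percentage points higher from compound 2 to compound 3 (beyond the scatter), with wide uncertainty. Compound 3 is estimated at 65%, range 42% to 88%.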

Compound 3, largest response reached (reported as efficacy), in percent of the reference or control that the assay uses: 74%
Compound 3: the middle estimate sits 9 percentage points below what was measured; the range from low to high includes it.
By their numbers in this assay, from the lowest: compound 2; then compounds 3 and 1 (each within the scatter of the next).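

In this assay, 4-fluorophenyl in place of 3-cyanophenyl on this carbon gives a number 26 percentage points higher from compound 2 to compound 3 (beyond the scatter), so the lower response of compound 2 does not extend to every substituted phenyl here. 4-fluorophenyl in place of 2-methylphenyl gives a number 8 percentage points lower from compound 1 to compound 3 (within the scatter), leaving these two groups unseparated and, among the three compounds, only the 3-cyanophenyl of compound 2 apart. No supporting evidence bears on this difference. Open, on these data alone, is how a methoxy group, an amine or a carboxylic acid in place of the nitrile would read, and where unsubstituted phenyl would fall.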